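The source may report more compounds than this note shows. Statements on the series, on what has been measured and on what is new or still open speak of the compounds shown alone.

Compound 3 `O=c1oc2cc(-c3cnc4[nH]ccc4c3)ccc2n1Cc1cccc(F)c1` gives 5920 nM in a functional assay on HCT-116 cells (Homo sapiens) for inhibition, read by MTT assay, with a stated time of 72 h; on this read-out higher numbers stand for weaker inhibition and lower numbers for stronger inhibition. Of the two numbers available it is the lower, and its nearest neighbour is compound 1 `N#Cc1cc(-c2ccc3c(c2)oc(=O)n3Cc2ccc(F)cc2)cnc1N`, which in this assay gives 8250 nM, a gap that lies within the scatter of repeated measurements, so no ranking of the two can be drawn from it. Compound 2 `O=c1oc2cc(-c3ccnc4[nH]ncc34)ccc2n1Cc1ccc(F)cc1` returns in this assay only a limit of > 100000 nM and no number; this is the limit of > 100000 nM in this assay, at which 1 of the 3 values shown sits. Going by the values given here, the single measured step, an at least 12-fold higher number from compound 1 to compound 2 (1.08 log units; beyond the scatter), exchanges one bicyclic heteroaryl group for another on the shared core and leaves the benzyl substituent untouched.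

Compound 4 `COc1cccc(Cn2c(=O)oc3cc(-c4cnc5[nH]ccc5c4)ccc32)c1` differs from compound 3 in one place: methoxy in place of fluoro on an aromatic carbon. Among the compounds with values here, no measured step among the three compounds touches the substituent on the benzyl ring; the only step in hand concerns a different part of the molecule and so gives no guide to the direction or size of this change. The step is therefore expected to remain within the scatter, a 1.0-fold higher number from compound 3 to compound 4 (0.01 log units; within the scatter). Compound 4 is accordingly estimated at 6000 nM in this assay, with a range from 2500 nM to 15000 nM.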

Compound 4, half-maximal inhibitory concentration: 5000 nM
Compound 4: the middle estimate sits 1.2-fold (0.08 log units) above what was measured, and the stated range covers the measured number.
By their numbers in this assay, from the lowest: compounds 4, 3 and 1 (each within the scatter of the next). At a limit, above all of these: compound 2.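

In this assay, replacing 3-fluorobenzyl with 3-methoxybenzyl on the shared core gives a 1.2-fold lower number from compound 3 to compound 4 (0.07 log units; within the scatter). Going by these compounds alone, this is the first measured step at this place on the benzyl ring, a carbon of a six-membered aromatic ring meta to a large group, as the only earlier step concerned a different part of the molecule. It shows that, with this heteroaryl group in place, fluoro and methoxy cannot be told apart at this position by this read-out, even though methoxy brings one more heavy atom and a hydrogen-bond acceptor; nothing available explains this result.

The compounds shown hold only these two substituents at this place with this heteroaryl group, so they leave open whether an amine, a carboxylic acid or a longer alkoxy chain there would move the number beyond the scatter. They also leave open whether the exchange of fluoro for methoxy would read the same with the heteroaryl group of compound 1 on the shared core.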